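From compound 3 to compound 4: a methyl added

The source may hold more compounds than are shown below. What is called first, only, known or untested is meant among the compounds shown, and "the series" means these compounds.

Going by the values given here, in a functional assay on PBM cells (Homo sapiens) for cytotoxicity (a lower number here means a stronger inhibitor, a higher number a weaker inhibitor), compound 1 `Nc1nc(=O)n([C@H]2C=C[C@@H](CO)O2)cc1Br` gives 91600 nM, the only true number so far. Compound 2 `CC(=O)OC[C@@H]1C=C[C@H](n2cc(F)c(N)nc2=O)O1` returns only a limit, > 100000 nM. Compound 3 `CCCC(=O)OC[C@@H]1C=C[C@H](n2cc(F)c(N)nc2=O)O1` also returns only a limit, > 100000 nM. Compound 3 therefore has no number of its own, and its place on the scale is the limit of > 100000 nM in this assay, at which 2 of the 3 values shown sit.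

Compound 4 `CCCCC(=O)OC[C@@H]1C=C[C@H](n2cc(F)c(N)nc2=O)O1` differs from compound 3 by methyl in place of hydrogen on a saturated chain carbon, three bonds along the chain from a carbonyl carbon. This is methyl in place of hydrogen on a saturated chain carbon, three bonds along the chain from a carbonyl carbon. The same difference, cut one bond further out, reads propyl to butyl.

Among the compounds with values here, the only measured step that bears on this change is a step that the two limits leave unreadable from compound 2 to compound 3, with ethyl in place of hydrogen on a saturated chain carbon bound to a carbonyl carbon. That step has no readable size to carry over, so no change beyond the scatter is expected in this assay, in either direction. The step expected is a number no higher from compound 3 to compound 4 (the limit leaves the size open). A reported limit is the likeliest result for the new compound.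

Compound 4 is estimated at 100000 nM, with an expected range from 50000 nM to 200000 nM.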

Compound 4, half-maximal inhibitory concentration: > 100000 nM
Compound 4: only a limit was reported (the forecaster's own chance of this, stated with the estimate: 75%); the middle value lies on the limit itself.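

In this assay compound 4 returns > 100000 nM as a limit, so its steps from compound 2 and from compound 3 join limit to limit and neither can be read. The compounds shown leave open whether the different chains of compound 2, compound 3 and compound 4 change the value at all, and where each truly stands: the limit of > 100000 nM in this assay, at which 3 of the 4 values shown sit.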